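The source may hold more compounds than are shown below. What is called first, only, known or untested is meant among the compounds shown, and "the series" means these compounds.

Measured compounds:

Compound 1, `CC1=C(/C=C/C(=O)/C=C/c2cccc(F)c2)C(C)(C)CCC1`, gives 18700 nM.
Compound 2, `CC1=C(/C=C/C(=O)/C=C/c2cccc([N+](=O)[O-])c2)C(C)(C)CCC1`, gives 10000 nM.
Compound 3, `CC1=C(/C=C/C(=O)/C=C/c2ccc(F)cc2)C(C)(C)CCC1O`, gives 6200 nM.

All three were tested in a functional assay on PC-3 cells (Homo sapiens) for cytotoxicity, read by MTT assay, with a stated time of 72 h; a lower number here means a stronger inhibitor, a higher number a weaker inhibitor. Compound 1 and compound 2 share one core and differ in a single place: nitro in place of fluoro on an aromatic carbon. That change gave a 1.9-fold lower number from compound 1 to compound 2 (0.27 log units; within the scatter). Compound 3 has a different core; how its core differs from that of compound 1 is not broken down here. Its value lies close to that of compound 2, while compound 1 shows a clearly higher number than compound 3.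

Compound 4, `CC1=C(/C=C/C(=O)/C=C/c2ccc([N+](=O)[O-])cc2)C(C)(C)CCC1O`, has not yet been measured in this assay. It differs from compound 3 in one place: nitro in place of fluoro on an aromatic carbon. Within the data shown here, this is the same kind of change as the one from compound 1 to compound 2, but not the same: in compound 2 the entering group sits meta to a large group, whereas in compound 4 it sits para to a large group.

The expectation for compound 4 rests on that earlier step, because a 1.9-fold lower number from compound 1 to compound 2 (0.27 log units; within the scatter) was small, and compound 3 already gives the lowest of the three numbers. The estimated step is a 1.6-fold lower number from compound 3 to compound 4 (0.19 log units; within the scatter), which is expected to stay within the scatter. Compound 4 is therefore estimated to give 4000 nM in this assay, expected to fall between 1500 nM and 10000 nM.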

Compound 4, half-maximal inhibitory concentration: 15000 nM
Compound 4: middle estimate off by 3.8-fold (0.57 log units), on the low side, outside the stated range (above it).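

Placing nitro where fluoro stood gave a 2.4-fold higher number from compound 3 to compound 4 (0.38 log units; beyond the scatter) in this assay, so the number moved the opposite way from the earlier step and by enough to lie beyond the usual variation between repeats. The same swap therefore did not carry over from one core to the other here, either in direction or in size, and a result from one core could not be used as a simple guide for the other: the same change on two cores in this assay, a 1.9-fold lower number (0.27 log units; within the scatter) from compound 1 to compound 2 and a 2.4-fold higher number (0.38 log units; beyond the scatter) from compound 3 to compound 4, 4.5-fold (0.66 log units) apart, beyond the scatter of two such steps

This does not show why the two steps part ways, nor that nitro is generally better or worse than fluoro in this series, since the two pairs differ both in their core and in where the group sits on the aromatic ring, and each pair is a single comparison.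

The compounds shown leave open how much of the gap belongs to the core and how much to the place on the ring, a question that needs the same swap at the same place on both cores. They also leave open how other groups on the aromatic ring, such as an amine, a methoxy group or a carboxylic acid, would behave on either core.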